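Phenyl for ethyl on the diene amide

A few compounds are considered here, and "the series" means these few. Any claim that something is new, unique, unknown or untested is made for them only; others in the source may bear on it.

Compound 3 `CC/C(=C\C=C\C(=O)N[C@H](C)CCCc1cccnc1)c1ccc(OC)cc1` gives 0.68 mg/kg in a functional assay with platelet-activating factor receptor (Cavia porcellus) as the target (on this read-out higher numbers stand for an effect only at larger amounts of compound and lower numbers for an effect already at smaller amounts), level with compound 1 `CCCC/C(=C\C=C\C(=O)N[C@H](C)CCCc1cccnc1)c1ccc(OC)cc1` at 0.68 mg/kg and together with it the highest of three numbers; compound 2 `CCCCCCCC/C(=C\C=C\C(=O)N[C@H](C)CCCc1cccnc1)c1ccc(OC)cc1` gives 0.1 mg/kg. Compound 4 `COc1ccc(/C(=C/C=C/C(=O)N[C@H](C)CCCc2cccnc2)c2ccccc2)cc1` carries phenyl in place of ethyl on a double-bonded chain carbon bound to an aromatic carbon and a double-bonded chain carbon. Among the compounds with values here, two steps bear on this: no change at the digits printed from compound 1 to compound 3 (within the scatter), and a 6.8-fold higher number from compound 2 to compound 3 (0.83 log units; beyond the scatter), so removing the short chain left the read-out unchanged while the longer chain mattered, as a 6.8-fold lower number from compound 1 to compound 2 (0.83 log units; beyond the scatter) also shows. No aromatic substituent at this carbon has been measured, so the effect is estimated only loosely; a phenyl is larger than ethyl but is not a chain. Compound 4 is expected to show a 1.7-fold lower number from compound 3 to compound 4 (0.23 log units; within the scatter), giving an estimated 0.4 mg/kg with a range of 0.12 mg/kg to 1.3 mg/kg.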

Compound 4, dose for 50% inhibition: 0.16 mg/kg
Compound 4: middle estimate off by 2.5-fold (0.40 log units), on the high side; the range from low to high includes it.
By their numbers in this assay, from the lowest: compounds 2 and 4 (each within the scatter of the next); then compounds 1 and 3 (each within the scatter of the next).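

In this assay, this position accepts an aromatic ring as well as a chain: phenyl in place of ethyl gives a 4.3-fold lower number from compound 3 to compound 4 (0.63 log units; beyond the scatter), and phenyl in place of butyl gives a 4.3-fold lower number from compound 1 to compound 4 (0.63 log units; beyond the scatter). Phenyl in place of octyl gives a 1.6-fold higher number from compound 2 to compound 4 (0.20 log units; within the scatter), so a single ring here matches the longest chain shown within the scatter. Nothing available accounts for these steps. The compounds shown leave open whether a saturated cyclohexyl ring would do the same as phenyl, and whether a fluorophenyl or pyridyl group would shift the number further from that of compound 4.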